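Extending the benzyl group of compound 2 with a chlorophenyl ring

The source may hold more compounds than are shown below. What is called first, only, known or untested is meant among the compounds shown, and "the series" means these compounds.

Measured so far:
compound 1, `Cc1ccc(CNc2nc(-c3ccccc3C(F)(F)F)nc3ccccc23)s1`: 5100 nM
compound 2, `FC(F)(F)c1ccccc1-c1nc(NCc2ccc(Cl)cc2)c2ccccc2n1`: 4800 nM

In an assay on a protein complex for inhibition of ubiquitin carboxyl-terminal hydrolase 1/WD repeat-containing protein 48 (Homo sapiens), read by fluorescence (on this read-out higher numbers stand for weaker inhibition and lower numbers for stronger inhibition), compound 2 gives the lowest of the two numbers, with compound 1 the nearest at 5100 nM; the two lie within the scatter of each other. Going by the values given here, the one measured step, a 1.1-fold lower number from compound 1 to compound 2 (0.03 log units; within the scatter), is small and says nothing about the part of the molecule that changes next.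

Compound 3, `FC(F)(F)c1ccccc1-c1nc(NCc2ccc(-c3cccc(Cl)c3)cc2)c2ccccc2n1`, differs from compound 2 as follows: 3-chlorophenyl in place of chloro on an aromatic carbon. Among the compounds with values here, no measured pair shows what extending this position with a further aromatic ring does, so the expected step of a 1.2-fold lower number from compound 2 to compound 3 (0.08 log units; within the scatter) cannot be argued from the data and is set close to no change, with a wide range. Compound 3 is therefore estimated at 4000 nM in this assay, between 1000 nM and 16000 nM.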

Compound 3, half-maximal inhibitory concentration: 2700 nM
Beside the measured number, compound 3's estimate is 1.5-fold (0.17 log units) above it; the range from low to high includes it.
By their numbers in this assay, from the lowest: compounds 3, 2 and 1 (each within the scatter of the next).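

Compound 3 is the first of these compounds to change the chloro position, which is para to a large group, and the first to carry a further aromatic ring there. In this assay, replacing chloro with 3-chlorophenyl adds 7 heavy atoms and one six-membered aromatic ring of carbon only, yet the step is a 1.8-fold lower number from compound 2 to compound 3 (0.25 log units; within the scatter), so this position accepts the larger group without a change beyond the scatter. No evidence at hand bears on the reason for this result.

From the compounds shown here alone, it remains open whether the chlorine on the added ring matters, and whether an unsubstituted phenyl, a carboxylic acid or an amine would behave the same way at this position. Whether moving that chlorine around the added ring would shift the number beyond the scatter is also unanswered.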